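A few compounds are considered here, and "the series" means these few. Any claim that something is new, unique, unknown or untested is made for them only; others in the source may bear on it.

Measured in a functional assay on cells (Homo sapiens) for antiproliferative activity, read by sulforhodamine B assay, with a stated time of 48 h; a lower number here means a stronger inhibitor, a higher number a weaker inhibitor:
- compound 1 `CCCCCCCCCCNC(=O)[C@@H]1CSC(c2ccc(OC)c(OC)c2)N1` gives 11900 nM
- compound 2 `CCCCCCCCCCCCNC(=O)[C@@H]1CSC(c2ccc(OC)c(OC)c2)N1` gives 2900 nM
- compound 3 `CCCCCCCCCCCCCCNC(=O)[C@@H]1CSC(c2ccc(OC)c(OC)c2)N1` gives 1500 nM

Compound 3, at 1500 nM in this assay, stands clear of compound 1, with a 7.9-fold lower number from compound 1 to compound 3 (0.90 log units; beyond the scatter) separating them. Compound 2 remains level with it, as a 1.9-fold lower number from compound 2 to compound 3 (0.29 log units; within the scatter) shows. The next compound is compound 4 `CCCCCCCCCCCCCCCCNC(=O)[C@@H]1CSC(c2ccc(OC)c(OC)c2)N1`, which differs from compound 3 by ethyl in place of hydrogen on a saturated chain carbon, ten or more bonds along the chain from an amide-type nitrogen on the same chain. The same ethyl for hydrogen change has been measured twice in this series. It gave a 4.1-fold lower number from compound 1 to compound 2 (0.61 log units; beyond the scatter) in one case and a 1.9-fold lower number from compound 2 to compound 3 (0.29 log units; within the scatter) in the other, and the second of these is the closer precedent. A small step towards a lower number is therefore expected in this assay, quite possibly none beyond the scatter. The expected step is a 1.4-fold lower number from compound 3 to compound 4 (0.13 log units; within the scatter) by this estimate. For compound 4 the estimated value is 1100 nM in the middle, with an expected range from 500 nM to 2600 nM as its ends.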

Compound 4, half-maximal inhibitory concentration: 1500 nM
Compound 4: middle estimate off by 1.4-fold (0.13 log units), on the low side; measured number inside the range.
By their numbers in this assay, from the lowest: compounds 3, 4 and 2 (each within the scatter of the next); then compound 1.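

In this assay, among the compounds shown here, ethyl in place of hydrogen on a saturated chain carbon, ten or more bonds along the chain from an amide-type nitrogen, now gives no change at the digits printed from compound 3 to compound 4 (within the scatter), and butyl in place of hydrogen at that place gives a 1.9-fold lower number from compound 2 to compound 4 (0.29 log units; within the scatter), so compounds 2, 3 and 4 stand level, while only the step out of compound 1 remains beyond the scatter, with hexyl giving a 7.9-fold lower number from compound 1 to compound 4 (0.90 log units; beyond the scatter). The ethyl change therefore does not carry the same size on every chain: the same change on two cores in this assay, a 4.1-fold lower number (0.61 log units; beyond the scatter) from compound 1 to compound 2 and no change at the digits printed (within the scatter) from compound 3 to compound 4, 4.1-fold (0.61 log units) apart, beyond the scatter of two such steps The butyl change behaves likewise: the same change on two cores in this assay, a 7.9-fold lower number (0.90 log units; beyond the scatter) from compound 1 to compound 3 and a 1.9-fold lower number (0.29 log units; within the scatter) from compound 2 to compound 4, 4.1-fold (0.61 log units) apart, beyond the scatter of two such steps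

From the compounds shown here alone, whether a longer chain than that of compound 4 would hold this level or lose it remains open. Also open, going by these compounds, is how an amine or a carboxylic acid on this chain would read in this assay.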